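Replacing the trifluoromethyl of compound 1 with methyl

The compounds below may be only part of what the source reports. "The series", "measured", "known", "first", "only" and "open" are said of these compounds alone.

Compound 1 `COc1cc2c(Oc3ccc(NC(=O)c4cc(-c5ccc(C(F)(F)F)cc5)ccn4)cc3F)ccnc2cc1OCCCN1CCCCC1` is the weakest of the three measured compounds in a functional assay on MKN-45 cells (Homo sapiens) for cytotoxicity, read by MTT assay, with a stated time of 72 h; a higher number here means a weaker inhibitor, a lower number a stronger inhibitor. In this assay compound 1 gives 870 nM, while compound 2 `COc1cc2c(Oc3ccc(NC(=O)c4cc(-c5ccc(C(F)(F)F)cc5)ccn4)cc3F)ccnc2cc1OCCCN1CCN(C)CC1` gives 330 nM and compound 3 `COc1cc2c(Oc3ccc(NC(=O)c4cc(-c5ccc(C(F)(F)F)cc5)ccn4)cc3F)ccnc2cc1OCCCN1CCCC1` gives 260 nM. Both measured steps away from compound 1 concern the amine at the end of the chain on the shared core: a 2.6-fold lower number from compound 1 to compound 2 (0.42 log units; beyond the scatter) and a 3.3-fold lower number from compound 1 to compound 3 (0.52 log units; beyond the scatter). Between compound 2 and compound 3 the difference is a 1.3-fold lower number from compound 2 to compound 3 (0.10 log units; within the scatter).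

Compound 4 `COc1cc2c(Oc3ccc(NC(=O)c4cc(-c5ccc(C)cc5)ccn4)cc3F)ccnc2cc1OCCCN1CCCCC1` keeps the piperidinyl chain of compound 1 and changes a different place: methyl in place of trifluoromethyl on an aromatic carbon of the ring that sits on the pyridine of the amide. Within the data shown here, none of the measured steps touches this ring, so no measured step bears directly on the change; the two steps that are known, a 2.6-fold lower number from compound 1 to compound 2 (0.42 log units; beyond the scatter) and a 3.3-fold lower number from compound 1 to compound 3 (0.52 log units; beyond the scatter), both sit on the chain amine and say nothing about the aryl substituent.

With no guidance, the expected step of a 1.1-fold higher number from compound 1 to compound 4 (0.06 log units; within the scatter) is small and uncertain in direction. For compound 4 in this assay, a value of 1000 nM is estimated, within a range of 300 nM to 3500 nM.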

Compound 4, half-maximal inhibitory concentration: 1670 nM
For compound 4 the middle estimate is 1.7-fold (0.22 log units) below the measured one; the range from low to high includes it.
By their numbers in this assay, from the lowest: compounds 3 and 2 (each within the scatter of the next); then compounds 1 and 4 (each within the scatter of the next).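

In this assay, among these compounds, the change from 4-(trifluoromethyl)phenyl to 4-methylphenyl gives the first reading at this ring, a 1.9-fold higher number from compound 1 to compound 4 (0.28 log units; within the scatter), so on the piperidin-1-yl chain of compound 1 this exchange of trifluoromethyl for methyl cannot be told apart from no change. The earlier steps had shown only that the amine at the end of the chain can move the number beyond the scatter, with a 2.6-fold lower number from compound 1 to compound 2 (0.42 log units; beyond the scatter) and a 3.3-fold lower number from compound 1 to compound 3 (0.52 log units; beyond the scatter), whereas this first step at the aromatic carbon, para to a large group, does not. No measurement is at hand that could explain the outcome at this position.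

What stays open is whether methyl and trifluoromethyl would also read alike on the shorter pyrrolidin-1-yl amine of compound 3 or the 4-methylpiperazin-1-yl amine of compound 2, since the compounds shown pair these two groups only on the piperidin-1-yl chain. They also leave open how this position would respond to a group other than these two, such as a chlorine, a methoxy or a nitrile, or to a plain hydrogen there.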